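This account rests on a few compounds, and the source may have more. Where it says the series, first, only, none or still open, it means among the compounds named here.

For the measured compounds named here, in a functional assay on HepG2 cells (Homo sapiens) for antiproliferative activity, read by MTT assay, with a stated time of 48 h (on this read-out lower numbers stand for an effect already at smaller amounts and higher numbers for an effect only at larger amounts of compound), compound 2 `COc1ccc(S(=O)(=O)N2N=C(C)CC2c2cc(Br)ccc2O)cc1` gives 38200 nM, the only actual number among the values so far. Compound 1 `CC1=NN(S(=O)(=O)c2ccccc2)C(c2cc(Br)ccc2O)C1` gives > 60000 nM, which is a limit of the assay and not a number. The next compound, compound 3 `CC1=NN(S(=O)(=O)c2ccc(C(F)(F)F)cc2)C(c2cc(Br)ccc2O)C1`, keeps the shared core and has trifluoromethyl in place of methoxy on an aromatic carbon, para to a large group: trifluoromethyl in place of methoxy on an aromatic carbon. Going by the values given here, only one measured step bears on this change: an at least 1.5-fold lower number from compound 1 to compound 2 (0.19 log units; that floor lies within the scatter), with methoxy in place of hydrogen on that same aromatic carbon. As far as these compounds go, this step is small, and it is known only as a floor, so its true size remains open. Among the compounds with values here, no measured compound yet carries trifluoromethyl. Within the data shown here, with only that step from compound 1 to compound 2 as a guide, no change beyond the scatter is expected in this assay, although a drift towards a higher number would not be surprising. The expected step is a 1.2-fold higher number from compound 2 to compound 3 (0.07 log units; within the scatter). For compound 3 the estimated value is 45000 nM, with an expected range from 20000 nM to 90000 nM.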

Compound 3, half-maximal effective concentration: 22100 nM
Beside the measured number, compound 3's estimate is 2.0-fold (0.31 log units) above it; the range from low to high includes it.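

In this assay, the change at this aromatic carbon, para to a large group, now gives a step that lies beyond the scatter: an at least 2.7-fold lower number from compound 1 to compound 3 (0.43 log units; beyond the scatter). As far as these compounds go, the true size of that step remains open because compound 1 stands at a limit of the assay and not at a number: the limit of > 60000 nM in this assay, at which 1 of the 3 values shown sits. The direct exchange of the two groups, a 1.7-fold lower number from compound 2 to compound 3 (0.24 log units; within the scatter), stays within the scatter, so the data do not separate trifluoromethyl from methoxy at this place, even though the two differ in heavy atoms and only methoxy counts a hydrogen-bond acceptor.

From the compounds shown here alone, it remains open whether the gain over hydrogen belongs to trifluoromethyl in particular or would come with other groups on this carbon, given that the step to methoxy is a floor that lies within the scatter. How an amine, a carboxylic acid or a longer chain would behave at this place is also open, and with all the numbers shown still high, these compounds do not say how far the value can fall through changes here.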